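Swapping an Aromatic Ring for Cyclohexyl

A few compounds are considered here, and "the series" means these few. Any claim that something is new, unique, unknown or untested is made for them only; others in the source may bear on it.

Measured in an ADME assay on microsomes from liver (Mus musculus) for metabolic stability, with a stated time of 10 min; on this read-out higher numbers stand for a more stable compound and lower numbers for a less stable compound
Compound 1 `O=C(O)C1CCN(C(=O)N2CC[C@](c3ccc(C(OCc4c(F)cccc4F)(C(F)(F)F)C(F)(F)F)cc3)(S(=O)(=O)c3ccc(F)cc3)C2)CC1` gives 84%
Compound 2 `O=C(O)[C@H]1CC[C@H](C(=O)N2CC[C@](c3ccc(C(OCc4ccccc4OC(F)(F)F)(C(F)(F)F)C(F)(F)F)cc3)(S(=O)(=O)c3ccc(F)cc3)C2)CC1` gives 81%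
Compound 3 `COc1cccc(F)c1COC(c1ccc([C@]2(S(=O)(=O)c3ccc(F)cc3)CCN(C(=O)[C@H]3CC[C@H](C(=O)O)CC3)C2)cc1)(C(F)(F)F)C(F)(F)F` gives 88%

Compound 3 (88%) has the highest of the three numbers, but it lies within the scatter of both compound 1 and compound 2. Compound 4 `O=C(O)[C@H]1CC[C@H](C(=O)N2CC[C@](c3ccc(C(OCC4CCCCC4)(C(F)(F)F)C(F)(F)F)cc3)(S(=O)(=O)c3ccc(F)cc3)C2)CC1` makes one change (cyclohexyl in place of 2-fluoro-6-methoxyphenyl on a saturated chain carbon bound to an oxygen on a saturated carbon), with cyclohexyl in place of 2-fluoro-6-methoxyphenyl on a saturated chain carbon bound to an oxygen on a saturated carbon. For the measured compounds named here, the one measured step at this place swapped one phenyl group for another (a number 7 percentage points higher from compound 2 to compound 3 (within the scatter)). Going by the values given here, no measured step replaces an aromatic ring with a non-aromatic one, so this guide is weak. In this assay a small downward step, not beyond the scatter, is expected. The estimated step is modest (a number 8 percentage points lower from compound 3 to compound 4 (within the scatter)). Compound 4 is estimated at 80% within an expected range of 60% to 92% in this measurement.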

Compound 4, percent of the compound remaining: 78%
The estimate for compound 4 lay 2 percentage points above the measured number; the measured number falls inside the stated range.
By their numbers in this assay, from the lowest: compounds 4, 2, 1 and 3 (each within the scatter of the next).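

A non-aromatic ring can take the place of an aromatic one here: cyclohexyl in place of 2-fluoro-6-methoxyphenyl gives a number 10 percentage points lower from compound 3 to compound 4 (within the scatter) and in place of 2-(trifluoromethoxy)phenyl gives a number 3 percentage points lower from compound 2 to compound 4 (within the scatter) in this assay as well. For the compounds shown here, the earlier compounds held only substituted phenyl groups at this place, so this is the first sign that the read-out tolerates a ring of another kind. No measurement shown explains this result.

Still open, going by these compounds, is whether a smaller ring such as cyclopentyl, an open hexyl chain or a cyclohexyl ring carrying an amine would give a number in the same range.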